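Thiophene in Place of Difluorophenyl on the Cyclopropane

The source may hold more compounds than are shown below. What is called first, only, known or untested is meant among the compounds shown, and "the series" means these compounds.

Compound 1 `CC[C@H](C)[C@H](N)CN(C(=O)[C@@H]1C[C@H]1c1ccccc1Cl)c1ccc(-c2ccccc2)cc1`, compound 2 `CC[C@H](C)[C@H](N)CN(C(=O)[C@@H]1C[C@H]1c1cc(F)cc(F)c1)c1ccc(-c2ccccc2)cc1`, compound 3 `CC[C@H](C)[C@H](N)CN(C(=O)[C@@H]1C[C@H]1c1c(F)cccc1F)c1ccc(-c2ccccc2)cc1`. In a functional assay for agonist activity at G protein-coupled receptor 88 (Homo sapiens), read by HTRF and cAMP accumulation (a lower number here means that less compound is needed, a higher number that more compound is needed for the effect), compound 2 gives 960 nM and compound 3 gives 11000 nM. Compound 1 in this assay reaches only a limit, > 25000 nM, which is the limit of > 25000 nM in this assay, at which 1 of the 3 values shown sits. Compound 3 therefore has the highest of the two numbers shown; the nearest is compound 2, with an 11-fold higher number from compound 2 to compound 3 (1.06 log units; beyond the scatter). Compound 4 `CC[C@H](C)[C@H](N)CN(C(=O)[C@@H]1C[C@H]1c1cccs1)c1ccc(-c2ccccc2)cc1` differs from compound 3 in thiophen-2-yl in place of 2,6-difluorophenyl on a saturated ring carbon. The measured steps bearing on this change are an at least 2.2-fold lower number from compound 1 to compound 3 (0.35 log units; beyond the scatter) and an 11-fold higher number from compound 2 to compound 3 (1.06 log units; beyond the scatter); both changes at the same ring carbon moved this assay beyond the scatter, so a step beyond the scatter toward a lower number is expected here as well. Compound 4 is estimated at 3000 nM, between 700 nM and 15000 nM, which means an expected step of a 3.7-fold lower number from compound 3 to compound 4 (0.56 log units; beyond the scatter).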

Compound 4, half-maximal effective concentration: 360 nM
Compound 4: the middle estimate sits 8.3-fold (0.92 log units) above what was measured; the measured number lies below the stated range.
By their numbers in this assay, from the lowest: compound 4; then compound 2; then compound 3. At a limit, above all of these: compound 1.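

In this assay, thiophen-2-yl on this saturated ring carbon gives a lower number than either difluorophenyl group: a 31-fold lower number from compound 3 to compound 4 (1.49 log units; beyond the scatter), and a 2.7-fold lower number from compound 2 to compound 4 (0.43 log units; beyond the scatter). The step from the 2-chlorophenyl group, an at least 69-fold lower number from compound 1 to compound 4 (1.84 log units; beyond the scatter), is read against a limit: the limit of > 25000 nM in this assay, at which 1 of the 4 values shown sits. The earlier compounds shown here all carried a substituted phenyl here, and compound 4 shows that a six-membered aromatic ring is not required at this position.

Whether the sulfur or the smaller ring accounts for this remains open. A furan-2-yl, thiophen-3-yl or unsubstituted phenyl group on the same carbon would bear on that question.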